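A few compounds are considered here, and "the series" means these few. Any claim that something is new, unique, unknown or untested is made for them only; others in the source may bear on it.

Measured compounds:
compound 1, `CCCCCCCCCCc1c(C)c(N(C)C)nc(C)c1O`, 60% in a functional assay on cells (Lymphocyte, Homo sapiens) for inhibition, read by flow cytometry, using a membrane potential dye, with a stated time of 16 h, tested at 100 nM; a higher number here means a stronger effect of the compound at the concentration tested, a lower number a weaker effect
compound 2, `CCCCCCCCCCc1nc(N(C)C)c(C)c(C)c1O`, 65% in this assay

Of the compounds shown here, two have numbers in this assay so far. Compound 1 gives 60%; compound 2 gives 65%. The gap between compound 2 and compound 1 lies within the usual scatter of this kind of measurement, so the two stand at about the same level and no order between them is claimed. Among the compounds with values here, no pair of the measured compounds differs in a single place, so no counted step is available.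

The next compound, compound 3, `CCCCCCCCCCCCCCCCc1nc(N(C)C)c(C)c(C)c1O`, is yet to be measured in this assay. It differs from compound 2 by hexyl in place of hydrogen on a saturated chain carbon, ten or more bonds along the chain from an aromatic carbon.

Within the data shown here, with no measured step that bears on such a change, the size and direction of the step cannot be taken from the series; the working assumption is a step of no more than the scatter, in either direction. Compound 3 is therefore expected near the level of compound 2, at 65%, within 35% to 85%, which means an expected no change at the digits printed from compound 2 to compound 3 (within the scatter).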

Compound 3, a percentage reported as activity, at one concentration (the size of the read-out at that concentration, not a potency): 67%
Estimate against measurement, compound 3: 2 percentage points below, and the stated range covers the measured number.
By their numbers in this assay, from the lowest: compounds 1, 2 and 3 (each within the scatter of the next).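

In this assay, within the data shown here, the first counted step is hexyl in place of hydrogen on a saturated chain carbon, ten or more bonds along the chain from an aromatic carbon, and it reads a number 2 percentage points higher from compound 2 to compound 3 (within the scatter). At this place, therefore, a group of 6 carbon atoms with no ring, no hydrogen-bond donors or acceptors and no net charge enters with the read-out staying at about the same level at the single concentration tested, something compounds 1 and 2 alone could not show. No measurement at hand bears on what lies behind this result.

From the compounds shown here alone, whether the level would hold with a carboxylic acid or an amine at this same place remains open, as does the effect of a shorter or still longer chain. The single-concentration read-out also leaves open whether compound 2 and compound 3 would stay level across a range of concentrations, so the step says nothing yet about potency.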